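The compounds below may be only part of what the source reports. "The series", "measured", "known", "first", "only" and "open" are said of these compounds alone.

Measured so far:
compound 1 `CC1=NN(C(=O)CCl)C(c2cc(Br)ccc2O)C1`, 8890 nM
compound 2 `CCC(=O)N1N=C(C)CC1c1cc(Br)ccc1O`, 37800 nM
compound 3 `CCC(=O)N1N=C(c2cc3ccccc3oc2=O)CC1c1ccccc1`, 4370 nM

All three were tested in a functional assay on PC-3 cells (Homo sapiens) for cytotoxicity, read by MTT assay, with a stated time of 48 h; a higher number here means a weaker inhibitor, a lower number a stronger inhibitor. Compound 1 and compound 2 share one core and differ in one place: chloro in place of methyl on a saturated chain carbon bound to a carbonyl carbon. That single exchange gives a 4.3-fold lower number from compound 2 to compound 1 (0.63 log units; beyond the scatter). Compound 3 is built on a different core; the difference between the two cores is not broken down here. Compound 3 gives 4370 nM, the lowest of the three numbers, beyond the scatter from both compound 1 and compound 2.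

Compound 4 `O=C(CCl)N1N=C(c2cc3ccccc3oc2=O)CC1c1ccccc1` has not yet been measured. It stands to compound 3 as compound 1 stands to compound 2: chloro in place of methyl on a saturated chain carbon bound to a carbonyl carbon. The place is described in the same words for both pairs, so this is the same change carried onto the second core.

For the measured compounds named here, because the step of a 4.3-fold lower number from compound 2 to compound 1 (0.63 log units; beyond the scatter) is modest but clearly beyond the scatter, a step of similar direction is expected here, estimated as a 3.6-fold lower number from compound 3 to compound 4 (0.56 log units; beyond the scatter), though only one earlier example supports it. Compound 4 is therefore expected to give about 1200 nM in this assay, estimated between 400 nM and 3500 nM.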

Compound 4, half-maximal inhibitory concentration: 2980 nM
The estimate for compound 4 lay 2.5-fold (0.40 log units) below the measured number; the measured number falls inside the stated range.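

On the core of compound 3, putting chloro in place of methyl on a saturated chain carbon bound to a carbonyl carbon gives a 1.5-fold lower number from compound 3 to compound 4 (0.17 log units; within the scatter) in this assay, a step too small to count as a real change. The same exchange therefore does not carry over from one core to the other at the same size: the same change on two cores in this assay, a 4.3-fold lower number (0.63 log units; beyond the scatter) from compound 2 to compound 1 and a 1.5-fold lower number (0.17 log units; within the scatter) from compound 3 to compound 4, 2.9-fold (0.46 log units) apart, beyond the scatter of two such steps

For the compounds shown here, with only two matched pairs, this shows that the size of the step differed between these two cores, but it does not show which part of the cores accounts for that difference or how the exchange would behave on any third core.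

The compounds shown leave open how an amine or a longer chain at this same place would read in this assay on either core. They also leave open whether the gap between the two steps would hold in a different cell line or at a different stated time.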